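From 2-Fluorobenzyl to 3-Carboxybenzyl on a Shared Core

A few compounds are considered here, and "the series" means these few. Any claim that something is new, unique, unknown or untested is made for them only; others in the source may bear on it.

In a functional assay on KARPAS-299 cells (Homo sapiens) for cytotoxicity, read by XTT assay, with a stated time of 72 h (a lower number here means a stronger inhibitor, a higher number a weaker inhibitor), compound 1 `Cn1cc(-c2cnc3[nH]cc(-c4cnn(Cc5ccccc5)c4)c3c2)cn1` gives 3000 nM. Compound 2 `Cn1cc(-c2cnc3[nH]cc(-c4cnn(Cc5ccccc5F)c4)c3c2)cn1`, which carries one added fluoro group, gives 2090 nM. The measured step is a 1.4-fold lower number from compound 1 to compound 2 (0.16 log units; within the scatter), so the two numbers cannot be told apart, and compound 2 stands level with compound 1 in this small set.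

Compound 3 `Cn1cc(-c2cnc3[nH]cc(-c4cnn(Cc5cccc(C(=O)O)c5)c4)c3c2)cn1` keeps the shared core and differs from compound 2 in one place: 3-carboxyphenyl in place of 2-fluorophenyl on a saturated chain carbon bound to an aromatic nitrogen. Put simply, it has 3-carboxyphenyl in place of 2-fluorophenyl on a saturated chain carbon bound to an aromatic nitrogen. Within the data shown here, only one measured step bears on this change, the swap of fluoro for hydrogen on an aromatic carbon, and it stayed within the scatter. Among the measured compounds shown here, that step offers little guidance, since no measured compound here carries a carboxy group. A modest move toward a weaker number is therefore expected, though with wide uncertainty, and the expected change is a 2.9-fold higher number from compound 2 to compound 3 (0.46 log units; beyond the scatter). For compound 3, the estimated value in this assay is 6000 nM, with an expected range from 1800 nM to 25000 nM.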

Compound 3, half-maximal inhibitory concentration: > 10000 nM
Compound 3 was reported as a limit; the forecaster's own chance of this, stated with the estimate: 20%; middle value at least 1.6-fold (0.22 log units) from the limit.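

Compound 3 stands in this assay only as a limit of the assay and not as a number, and it is the one compound shown that reaches it: the limit of > 10000 nM in this assay, at which 1 of the 3 values shown sits. Going from 2-fluorobenzyl to 3-carboxybenzyl gives an at least 4.7-fold higher number from compound 2 to compound 3 (0.67 log units; beyond the scatter), and going from plain benzyl to 3-carboxybenzyl gives an at least 3.3-fold higher number from compound 1 to compound 3 (0.52 log units; beyond the scatter). The earlier fluoro step stayed within the scatter and so could not show whether the number responds to a change on this benzyl group at all, whereas the carboxy compound now separates from both other compounds, toward the weaker side, and the size of that move has only a lower bound.

From the compounds shown here alone, how far the number really rises stays open, and so does whether the carboxylic acid itself matters or only the larger 3-carboxyphenyl group that enters at this place. A methyl ester, a primary amide or an amine on the same benzyl group could separate these readings, and the compounds shown do not say whether any group here would give a number clearly lower than those of compound 1 and compound 2.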